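The source may hold more compounds than are shown below. What is called first, only, known or untested is meant among the compounds shown, and "the series" means these compounds.

Working notes on the series. In a functional assay on ECa-109 cells for inhibition, with ECa-109 cell line (Homo sapiens) as the target, read by MTT assay, with a stated time of 48 h (on this read-out lower numbers stand for stronger inhibition and higher numbers for weaker inhibition), compound 1 (`COc1cccc(Nc2nnc(Cl)c(Nc3cc(OC)c(OC)c(OC)c3)n2)c1`) gives 15900 nM and compound 2 (`COc1cc(Nc2nc(Nc3ccccc3)nnc2Cl)cc(OC)c1OC`) gives 12600 nM. Compound 1 therefore has a single neighbour on the numbers, and the two values lie within the scatter of each other.

Compound 3 (`COc1cc(Nc2nc(Nc3ccc(C(C)=O)cc3)nnc2Cl)cc(OC)c1OC`) is not yet measured. It differs from compound 1 as follows: 4-acetylphenyl in place of 3-methoxyphenyl on a nitrogen on an aromatic ring.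

Among the compounds with values here, one measured step bears on this change, the one to compound 2, with hydrogen in place of methoxy on an aromatic carbon: a 1.3-fold lower number from compound 1 to compound 2 (0.10 log units; within the scatter). Removing the methoxy thus left the number within the scatter. Within the data shown here, no measured compound carries the acetyl, so the data give no direction for that part of the change.

No step beyond the scatter is expected, and the estimated step is a 1.2-fold lower number from compound 1 to compound 3 (0.09 log units; within the scatter). Compound 3 is expected at 13000 nM, with an estimated range of 5000 nM to 32000 nM.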

Compound 3, half-maximal inhibitory concentration: 36300 nM
Compound 3: the middle estimate sits 2.8-fold (0.45 log units) below what was measured; the measured number lies above the stated range.
By their numbers in this assay, from the lowest: compounds 2 and 1 (each within the scatter of the next); then compound 3.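

In this assay, within the data shown here, the group on this nitrogen moves the number beyond the scatter for the first time: acetyl in place of hydrogen on an aromatic carbon gives a 2.9-fold higher number from compound 2 to compound 3 (0.46 log units; beyond the scatter), and 4-acetylphenyl in place of 3-methoxyphenyl gives a 2.3-fold higher number from compound 1 to compound 3 (0.36 log units; beyond the scatter). The earlier pair showed only a step within the scatter, whereas these two modest steps show that this position does respond to what it carries, with the acetyl going towards weaker inhibition. Nothing measured here accounts for this rise.

With the acetyl in 4-acetylphenyl and the methoxy in 3-methoxyphenyl, the compounds shown do not separate the identity of the group from its place on the ring. On these data alone, it also remains open whether an amine or a carboxylic acid in place of the acetyl would move the number the same way.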